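A few compounds are considered here, and "the series" means these few. Any claim that something is new, unique, unknown or untested is made for them only; others in the source may bear on it.

In an assay on IMR-32 cells for inhibition of Voltage-dependent N-type calcium channel subunit alpha-1B (Homo sapiens) (on this read-out higher numbers stand for weaker inhibition and lower numbers for stronger inhibition), compound 1 `CN1CCc2c(ccc(CN3CCCCCC3)c2O)C1` gives > 100000 nM, and this is a limit of the assay rather than a measured number. Compound 2 `Oc1c(CN2CCCCCC2)ccc2c1CCN(CCCC(c1ccccc1)c1ccccc1)C2` carries a long chain ending in two phenyl rings on the ring nitrogen of the shared core, and in this assay compound 2 gives 460 nM. Among the results shown, that is the only true number for compound 2 to be measured against; the value of compound 1 sits at the limit of > 100000 nM in this assay, at which 1 of the 2 values shown sits. Compound 3 `Oc1c(CN2CCCCCC2)ccc2c1CCN(CCCCc1ccccc1)C2` differs from compound 2 by hydrogen in place of phenyl on a saturated chain carbon bound to an aromatic carbon and a saturated chain carbon. Among the compounds with values here, no step between two measured compounds is available to gauge the effect of this change. Within the data shown here, the only guide is the contrast between the full chain of compound 2 and the bare methyl of compound 1, which gives > 100000 nM as a limit. Trimming one phenyl is therefore expected to move the result toward weaker inhibition, by a step of a 6.5-fold higher number from compound 2 to compound 3 (0.81 log units; beyond the scatter) from compound 2 to compound 3, beyond the usual scatter. Compound 3 is estimated to give 3000 nM in this assay, within a range from 800 nM to 15000 nM.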

Compound 3, half-maximal inhibitory concentration: 15000 nM
Compound 3: the middle estimate sits 5.0-fold (0.70 log units) below what was measured, and the stated range covers the measured number.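

In this assay, the change of hydrogen in place of phenyl on a saturated chain carbon bound to an aromatic carbon and a saturated chain carbon gives a 33-fold higher number from compound 2 to compound 3 (1.51 log units; beyond the scatter), so the second phenyl ring matters a great deal at this position, and losing it is no minor trim. The single phenyl left on the chain still keeps part of the inhibition, since 3-phenylpropyl in place of hydrogen on a saturated chain carbon bound to an amine nitrogen in a ring gives an at least 6.6-fold lower number from compound 1 to compound 3 (0.82 log units; beyond the scatter). Compound 1 stands at a limit of the assay and not at a true number, so this second step gives only a minimum size: the limit of > 100000 nM in this assay, at which 1 of the 3 values shown sits.

The compounds shown leave open whether the second phenyl must be an aromatic ring at all, or whether a cyclohexyl ring or a plain methyl at the same carbon would keep some of the inhibition. They also leave open how a longer chain carrying the two phenyl rings, or an amine or a carboxylic acid on one of those rings, would change the result.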